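Moving a Methoxy Group on an Amide-Bearing Core

The source may hold more compounds than are shown below. What is called first, only, known or untested is meant among the compounds shown, and "the series" means these compounds.

Three compounds share one core and differ only in the group attached to the carbonyl carbon of the amide. In a functional assay on HCT-116 cells (Homo sapiens) for antiproliferative activity, read by MTT assay, with a stated time of 72 h (on this read-out lower numbers stand for stronger inhibition and higher numbers for weaker inhibition), compound 1 `CC(=O)N(C)c1ccc2[nH]c(-c3n[nH]c4ccccc34)cc2n1` gives 14800 nM. Compound 2 `CN(C(=O)c1ccc(Cl)cc1)c1ccc2[nH]c(-c3n[nH]c4ccccc34)cc2n1` gives 3000 nM in this assay, and compound 3 `COc1ccc(C(=O)N(C)c2ccc3[nH]c(-c4n[nH]c5ccccc45)cc3n2)cc1` gives 29500 nM in this assay, the highest of the three numbers. The step of a 4.9-fold lower number from compound 1 to compound 2 (0.69 log units; beyond the scatter) is beyond the scatter, the step of a 2.0-fold higher number from compound 1 to compound 3 (0.30 log units; within the scatter) is within it, and the step of a 9.8-fold higher number from compound 2 to compound 3 (0.99 log units; beyond the scatter) is beyond it.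

Compound 4 `COc1cccc(C(=O)N(C)c2ccc3[nH]c(-c4n[nH]c5ccccc45)cc3n2)c1` differs from compound 3 by 3-methoxyphenyl in place of 4-methoxyphenyl on a carbonyl carbon. Within the data shown here, no measured step shows a methoxy group moved within its ring, so the only guidance is the general spread of the groups tried so far, in which compound 1 and compound 3 sit within the scatter of each other. The step of a 1.5-fold lower number from compound 3 to compound 4 (0.17 log units; within the scatter) is therefore expected to fall within the scatter, with no clear direction. Compound 4 is estimated at 20000 nM, with a range from 6000 nM to 60000 nM.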

Compound 4, half-maximal inhibitory concentration: 14200 nM
Estimate against measurement, compound 4: 1.4-fold (0.15 log units) above, within the range that was stated.
By their numbers in this assay, from the lowest: compound 2; then compounds 4, 1 and 3 (each within the scatter of the next, the first and the last beyond it).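

Moving the methoxy group from 4-methoxyphenyl to 3-methoxyphenyl on the carbonyl carbon gives a small but readable change in this assay (a 2.1-fold lower number from compound 3 to compound 4 (0.32 log units; beyond the scatter)), the first sign here that the place of this group on its ring matters and not only its presence. The 3-methoxyphenyl group still falls short of the 4-chlorophenyl group (a 4.7-fold higher number from compound 2 to compound 4 (0.68 log units; beyond the scatter)), while it cannot be told apart from the plain methyl group (a 1.0-fold lower number from compound 1 to compound 4 (0.02 log units; within the scatter)), so neither methoxy compound approaches compound 2. Nothing measured here speaks to why the position of the methoxy group changes the number.

As far as these compounds go, whether moving the chloro group of compound 2 within its ring would have any similar effect stays open. Also open, from the compounds shown here alone, is what an amine or a carboxylic acid on that ring would give.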